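Swapping Chloro for Methoxy: Expected Cell Tolerance

The compounds below may be only part of what the source reports. "The series", "measured", "known", "first", "only" and "open" are said of these compounds alone.

Of the compounds shown here, three sharing one core have been tested in an ADME assay on MDCK cells (Canis lupus familiaris) for cytotoxicity, read by MTT assay; a lower number here means that less compound is tolerated, a higher number that more compound is tolerated. Compound 1 `O=c1cc(-c2ccccc2Cl)oc2ccccc12` gives 388000 nM in this assay. Compound 3 `COc1ccccc1-c1cc(=O)c2ccccc2o1` gives 171000 nM. Between them stands one change, (methoxy in place of chloro on an aromatic carbon), and it produced a 2.3-fold lower number from compound 1 to compound 3 (0.36 log units; beyond the scatter). Compound 2 `O=c1cc(-c2cccc(Cl)c2)oc2ccccc12` gives 174000 nM; how its core differs from the core of compound 1 is not broken down here. The values of compound 2 and compound 3 sit within the scatter of each other.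

Compound 4 `COc1cccc(-c2cc(=O)c3ccccc3o2)c1` has not yet been measured. It differs from compound 2 by methoxy in place of chloro on an aromatic carbon. For the measured compounds named here, this is the same kind of change as the one from compound 1 to compound 3, though not the same: in the earlier pair the place is ortho to a large group, here it is meta to a large group. Going by the values given here, the expectation for compound 4 is a step of about a 1.7-fold lower number from compound 2 to compound 4 (0.24 log units; within the scatter), resting on the earlier pair because a 2.3-fold lower number from compound 1 to compound 3 (0.36 log units; beyond the scatter) is the only guide available. Compound 4 is therefore estimated at 100000 nM, with a likely range from 50000 nM to 250000 nM.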

Compound 4, half-maximal cytotoxic concentration: 263000 nM
Estimate against measurement, compound 4: 2.6-fold (0.42 log units) below; measured number above the stated range.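

In this assay, methoxy in place of chloro on an aromatic carbon gives a 1.5-fold higher number from compound 2 to compound 4 (0.18 log units; within the scatter), so on this core the swap leaves the number within the ordinary variation of repeated measurements. Set beside the earlier pair, the same swap clearly does not behave as one fixed step that can be carried from one core to another: the same change on two cores in this assay, a 2.3-fold lower number (0.36 log units; beyond the scatter) from compound 1 to compound 3 and a 1.5-fold higher number (0.18 log units; within the scatter) from compound 2 to compound 4, 3.4-fold (0.54 log units) apart, beyond the scatter of two such steps What this does not show is why the two steps part, since the two pairs differ in their cores and also in where the change sits, and two pairs are too few to give a rule for any further core.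

Going by these compounds, it remains open how the number would respond if an amine, a carboxylic acid or a longer chain took the place of chloro or methoxy. For the compounds shown here, it also remains open whether a third core would follow the step seen with compound 1 and compound 3, the one seen with compound 2 and compound 4, or neither.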